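The source may report more compounds than this note shows. Statements on the series, on what has been measured and on what is new or still open speak of the compounds shown alone.

Of the compounds shown here, two sharing one core have been measured so far in a functional assay on T47D cells (Homo sapiens) for inhibition, read by CCK-8 assay, with a stated time of 72 h, tested at 10 uM; on this read-out lower numbers stand for less inhibition of growth and higher numbers for more inhibition of growth at the one concentration tested. Compound 1 `CN(C)C(=O)c1cc2cnc(Nc3ccc(NC(=O)C4(C(=O)Nc5cccc(F)c5)CC4)cc3)nc2n1C1CCCC1` gives -0.4%, while compound 2 `CN(C)C(=O)c1cc2cnc(Nc3ccc(NC(=O)C4(C(=O)Nc5ccc(Cl)c(C(F)(F)F)c5)CC4)cc3)nc2n1C1CCCC1` gives 55.8%, the higher of the two numbers and clearly apart from the other. Within the data shown here, the one measured step is a number 56.2 percentage points higher from compound 1 to compound 2 (beyond the scatter), a large move beyond the scatter, which came with 4-chloro-3-(trifluoromethyl)phenyl in place of 3-fluorophenyl on an amide-type nitrogen.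

Compound 3 `CN(C)C(=O)c1cc2cnc(Nc3ccc(NC(=O)C4(C(=O)Nc5cccc(Br)c5)CC4)cc3)nc2n1C1CCCC1` changes that same place again, and it has not yet been measured. Its difference from compound 2 is 3-bromophenyl in place of 4-chloro-3-(trifluoromethyl)phenyl on an amide-type nitrogen. The entering group matches neither group tested so far, and the evidence is thin. Still, the measured a number 56.2 percentage points higher from compound 1 to compound 2 (beyond the scatter) shows that this place can shift the number a great deal, so a sizeable drop is expected, going part of the way back towards compound 1. The expected change is a number 30.8 percentage points lower from compound 2 to compound 3 (beyond the scatter), a fall beyond the scatter, though one step cannot fix its size. For compound 3 the estimate is 25%, with an expected range from 3% to 52%.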

Compound 3, percent growth inhibition at one concentration: 94.6%
Compound 3: middle estimate off by 69.6 percentage points, on the low side, outside the stated range (above it).
By their numbers in this assay, from the lowest: compound 1; then compound 2; then compound 3.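

In this assay, the move to the 3-bromophenyl group gives a number 38.8 percentage points higher from compound 2 to compound 3 (beyond the scatter) even though the group that enters is the smaller by heavy-atom count, so a bigger group on this amide-type nitrogen does not simply mean a higher number. The sharper finding comes from the pair that differs by a single atom: bromo in place of fluoro on an aromatic carbon gives a number 95 percentage points higher from compound 1 to compound 3 (beyond the scatter) and takes the series from no measurable growth inhibition to the top of the three, which shows that the identity of one halogen on this ring can decide the result. No measured property of these groups is available to account for this order.

The three compounds leave open whether the effect is special to bromo or would also appear with a chloro or iodo group on that aromatic carbon, or with a non-halogen such as a methyl, a methoxy group or an amine. They also leave open how the compounds compare across a range of concentrations, since each number comes from a single one.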